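Extending the Nitrile Chain in a Level Cytotoxicity Series

The source may report more compounds than this note shows. Statements on the series, on what has been measured and on what is new or still open speak of the compounds shown alone.

In a functional assay on J82 cells (Homo sapiens) for cytotoxicity, read by colorimetric assay and MTT assay (on this read-out higher numbers stand for weaker inhibition and lower numbers for stronger inhibition), three compounds built on one shared core have been measured. Compound 1 `CCOC(=O)Cn1c(=O)c(-c2ccc(OC)cc2)cc2c(OC)cc(OC)cc21` gives 10000 nM, compound 2 `CCN(CC)C(=O)Cn1c(=O)c(-c2ccc(OC)cc2)cc2c(OC)cc(OC)cc21` gives 10000 nM, and compound 3 `COc1ccc(-c2cc3c(OC)cc(OC)cc3n(CC#N)c2=O)cc1` gives 10000 nM, so compound 3 stands level with the other two. Compound 4 `COc1ccc(-c2cc3c(OC)cc(OC)cc3n(CCCC#N)c2=O)cc1` carries 2-cyanoethyl in place of cyano on a saturated chain carbon bound to an aromatic nitrogen. Going by the values given here, three measured steps bear on this change. They are no change at the digits printed from compound 1 to compound 2 (within the scatter), no change at the digits printed from compound 1 to compound 3 (within the scatter) and no change at the digits printed from compound 2 to compound 3 (within the scatter), and none of them goes beyond the scatter. Among the compounds with values here, none of these steps extends the chain itself, so the data offer no direct precedent and the expectation rests on the level values alone. The expected step is no change at the digits printed from compound 3 to compound 4 (within the scatter), with no shift beyond the scatter in either direction. For compound 4 the estimate is 10000 nM. The expected range for compound 4 runs from 4000 nM to 15000 nM.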

Compound 4, half-maximal inhibitory concentration: 10000 nM
Compound 4: the middle estimate sits on the measured number at the digits printed; the measured number falls inside the stated range.
By their numbers in this assay, from the lowest: compounds 1, 2, 3 and 4 (each within the scatter of the next).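

In this assay, going by these compounds alone, lengthening the substituent from cyanomethyl to 3-cyanopropyl on a saturated chain carbon bound to an aromatic nitrogen gives no change at the digits printed from compound 3 to compound 4 (within the scatter) and is the first step to extend the chain while keeping the nitrile. The longer nitrile chain also reads level with both carbonyl-bearing substituents, with no change at the digits printed from compound 2 to compound 4 (within the scatter) against diethylcarbamoyl and no change at the digits printed from compound 1 to compound 4 (within the scatter) against ethoxycarbonyl. No measurement is available that would account for this flat reading.

Going by these compounds, it remains open whether an amine or a carboxylic acid at the end of the chain, or a chain longer than 3-cyanopropyl, would depart from this level. Also open, on these data alone, is whether hydroxy in place of methoxy on the shared core would do so.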